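Chloro for trifluoromethyl on the N-aryl of the pyridazinone amide

A few compounds are considered here, and "the series" means these few. Any claim that something is new, unique, unknown or untested is made for them only; others in the source may bear on it.

For the measured compounds named here, compound 2 `Cc1cc(=O)n(-c2ccccc2C(F)(F)F)nc1C(=O)Nc1ccc(Oc2ncnc3c2ccn3C)cc1` gives 27200 nM in a functional assay on HepG2 cells (Homo sapiens) for cytotoxicity, read by MTT assay, with a stated time of 72 h (on this read-out lower numbers stand for stronger inhibition and higher numbers for weaker inhibition), and stands at the lowest of the two numbers measured so far; its nearest neighbour is compound 1 `Cc1ccc(-n2nc(C(=O)Nc3ccc(Oc4ncnc5c4ccn5C)cc3)c(C)cc2=O)cc1`, which in this assay gives 33800 nM, a difference within the scatter. Going by the values given here, the one step measured, a 1.2-fold lower number from compound 1 to compound 2 (0.09 log units; within the scatter), exchanges the whole aryl on the ring nitrogen and still moves the number only within the scatter, so this part of the shared core has so far tolerated change without a clear shift. Compound 3 `Cc1cc(=O)n(-c2ccccc2Cl)nc1C(=O)Nc1ccc(Oc2ncnc3c2ccn3C)cc1` differs from compound 2 by chloro in place of trifluoromethyl on an aromatic carbon, a smaller change than the one already measured, on the same aryl. Among the compounds with values here, no measured step addresses a chloro in this place directly, so the only guide is the flat step from compound 1 to compound 2. In this assay compound 3 is therefore expected to sit close to compound 2, with a 1.0-fold higher number from compound 2 to compound 3 (0.01 log units; within the scatter) not exceeding the scatter in either direction. The estimate for compound 3 is 28000 nM, within a range from 12000 nM to 70000 nM.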

Compound 3, half-maximal inhibitory concentration: 11200 nM
Beside the measured number, compound 3's estimate is 2.5-fold (0.40 log units) above it; the whole stated range lies above it.
By their numbers in this assay, from the lowest: compound 3; then compounds 2 and 1 (each within the scatter of the next).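

In this assay, for the compounds shown here, the aryl on the ring nitrogen no longer reads as a flat point: chloro in place of trifluoromethyl gives a 2.4-fold lower number from compound 2 to compound 3 (0.39 log units; beyond the scatter) and is the first step here to pass the scatter, although it is only modest. The 2-chlorophenyl group also stands apart from the 4-methylphenyl group, with a 3.0-fold lower number from compound 1 to compound 3 (0.48 log units; beyond the scatter) on that comparison, so compound 3 carries the lowest number of the three, and this smaller change on the aryl registers where the exchange of the whole aryl did not. Nothing available accounts for this shift, so the result stays an observation on these compounds alone.

Going by these compounds, whether the step belongs to chloro specifically remains open, since only trifluoromethyl and chloro are compared on this aromatic carbon, and a fluoro, methoxy or amino group there could show whether the number moves further or returns. On these data alone, it is also open whether chloro at another place on the same ring, or a second chloro, would carry a step of similar size.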